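Ring swap on the pendant fluoropyridine of compound 1

The compounds below may be only part of what the source reports. "The series", "measured", "known", "first", "only" and "open" are said of these compounds alone.

Compound 1 `O=S(=O)(Nc1nccs1)c1ccc2c(c1)OCC[C@@H]2c1ccc(C(F)(F)F)cc1-c1ccc(F)cn1` gives 3.5 in a physicochemical assay for lipophilicity (on this read-out lower numbers stand for lower lipophilicity and higher numbers for higher lipophilicity), the highest of the three numbers measured here. Compound 2 `Cc1nc(-c2cc(C(F)(F)F)ccc2[C@@H]2CCOc3cc(S(=O)(=O)Nc4nccs4)ccc32)co1` gives 2.9 and compound 3 `Cn1nccc1-c1cc(C(F)(F)F)ccc1[C@H]1CCOc2cc(S(=O)(=O)Nc3cccnn3)ccc21` gives 2.2 in this assay; both gaps to compound 1 lie beyond the scatter. Compound 4 `O=S(=O)(Nc1nccs1)c1ccc2c(c1)OCC[C@@H]2c1ccc(C(F)(F)F)cc1-c1ccc(F)nc1` keeps the same atoms as compound 1, joined differently: 6-fluoropyridin-3-yl in place of 5-fluoropyridin-2-yl on an aromatic carbon on an aromatic carbon of a six-membered aromatic ring of carbon only, ortho to a large group and meta to a trifluoromethyl group. Within the data shown here, no step between measured compounds covers such a swap. A step in this assay from compound 1 to compound 4 of a number 0.10 log units higher from compound 1 to compound 4 (within the scatter) is expected, no larger than the scatter. Compound 4 is estimated at 3.6, with a range from 3.2 to 4.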

Compound 4, distribution coefficient: 3.2
For compound 4 the middle estimate is 0.40 log units above the measured one; low and high end bracket the measured number.
By their numbers in this assay, from the lowest: compound 3; then compounds 2, 4 and 1 (each within the scatter of the next, the first and the last beyond it).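

In this assay, 6-fluoropyridin-3-yl in place of 5-fluoropyridin-2-yl, on the aromatic carbon ortho to a large group and meta to a trifluoromethyl group, reads a number 0.30 log units lower from compound 1 to compound 4 (within the scatter). Among these compounds, this is the only pair here differing in one place, and at this position the two fluoropyridine isomers cannot be told apart on this read-out. Nothing available explains the step.

Open, going by these compounds, is whether a morpholine or a carboxylic acid at this carbon would shift the read-out beyond the scatter. Also open, on these data alone, is whether the same swap reads alike on a different sulfonamide.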